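Thiazolidinone series: aryl exchange on the saturated ring carbon

This account rests on a few compounds, and the source may have more. Where it says the series, first, only, none or still open, it means among the compounds named here.

Going by the values given here, compound 2 `O=C(CN1C(=O)c2ccccc2C1=O)NN1C(=O)CSC1c1c[nH]c2ccccc12` gives the higher of the two numbers so far: in a physicochemical assay for lipophilicity, in phosphate buffer, measured as octanol-water partition, with a stated time of 24 h (a lower number here means a more polar compound, a higher number a more lipophilic compound), compound 2 gives 1.59, while compound 1 `O=C(CN1C(=O)c2ccccc2C1=O)NN1C(=O)CSC1c1cccnc1` gives 1.25, the step being a number 0.34 log units higher from compound 1 to compound 2 (beyond the scatter). Compound 3 `O=C(CN1C(=O)c2ccccc2C1=O)NN1C(=O)CSC1c1ccc(Cl)cc1` differs from compound 2 by 4-chlorophenyl in place of 1H-indol-3-yl on a saturated ring carbon. Among the compounds with values here, no measured step covers this exchange; the one step known concerns a different pair of groups, so it offers only a loose guide to the size an aryl swap can bring. A modest rise beyond the scatter is nonetheless expected, a number 0.51 log units higher from compound 2 to compound 3 (beyond the scatter). Compound 3 is estimated at 2.1, within 1.6 to 2.6.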

Compound 3, partition coefficient: 3.21
Estimate against measurement, compound 3: 1.11 log units below; the whole stated range lies below it.
By their numbers in this assay, from the lowest: compound 1; then compound 2; then compound 3.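

On this saturated ring carbon, the aryl group can shift the numbers in this assay much further than the first exchange indicated: 4-chlorophenyl gives a number 1.62 log units higher from compound 2 to compound 3 (beyond the scatter) and a number 1.96 log units higher from compound 1 to compound 3 (beyond the scatter), both large, against the modest a number 0.34 log units higher from compound 1 to compound 2 (beyond the scatter). The three aryl groups shown are thus well separated, with 4-chlorophenyl at the top. Nothing available accounts for the size of these steps.

Going by these compounds, how much of the step belongs to the chlorine stays open without the plain phenyl group on the shared core. Also open, on these data alone, is the read-out with an amine or a carboxylic acid on the aryl ring.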